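Nitro for isopropyl on the anilide ring of the core

This account rests on a few compounds, and the source may have more. Where it says the series, first, only, none or still open, it means among the compounds named here.

Compound 3 `CC(C)c1ccccc1NC(=O)N1CCN(c2ccnc(Cl)n2)CC1` gives 7530 nM in an assay on isolated protein for antagonist activity at transient receptor potential cation channel subfamily V member 1 (Homo sapiens) (on this read-out higher numbers stand for weaker inhibition and lower numbers for stronger inhibition), the highest of the three numbers shown; compound 1 `O=C(Nc1ccccc1Br)N1CCN(c2ccnc(Cl)n2)CC1` gives 1070 nM and compound 2 `O=C(Nc1ccc(C(F)(F)F)cc1)N1CCN(c2ccnc(Cl)n2)CC1` gives 874 nM. The step to compound 4 `O=C(Nc1ccccc1[N+](=O)[O-])N1CCN(c2ccnc(Cl)n2)CC1` is nitro in place of isopropyl on an aromatic carbon. Within the data shown here, no measured pair swaps in a nitro group, so the step is not directly anchored. Among the measured compounds shown here, the one measured change at this place, a 7.0-fold higher number from compound 1 to compound 3 (0.85 log units; beyond the scatter), shows that the group on this aromatic carbon moves this assay by a modest amount, and the bromo analogue sits well below compound 3. A step back toward compound 1 is therefore expected, a 5.0-fold lower number from compound 3 to compound 4 (0.70 log units; beyond the scatter), with wide uncertainty. Compound 4 is estimated at 1500 nM, within 400 nM to 6000 nM.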

Compound 4, half-maximal inhibitory concentration: 854 nM
Estimate against measurement, compound 4: 1.8-fold (0.24 log units) above; the measured number falls inside the stated range.
By their numbers in this assay, from the lowest: compounds 4, 2 and 1 (each within the scatter of the next); then compound 3.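

In this assay, nitro in place of isopropyl on this aromatic carbon gives an 8.8-fold lower number from compound 3 to compound 4 (0.95 log units; beyond the scatter), a step larger than the one that first showed this position matters. Nitro in place of bromo gives a 1.3-fold lower number from compound 1 to compound 4 (0.10 log units; within the scatter), so among the three groups at this place only isopropyl stands apart, while two groups of different atoms read alike. No measurement here explains this separation. Going by these compounds, whether a methyl or a tert-butyl group would follow isopropyl remains open. So does whether an amine or a carboxylic acid at this place would stay with compound 1 and compound 4.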